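Acylation of the ring amine: a second pairing

The compounds below may be only part of what the source reports. "The series", "measured", "known", "first", "only" and "open" are said of these compounds alone.

Measured so far in a functional assay on NUGC-3 cells (Homo sapiens) for inhibition, read by sulforhodamine B assay, with a stated time of 48 h; on this read-out higher numbers stand for weaker inhibition of growth and lower numbers for stronger inhibition of growth:
- compound 1 `O=C(Nc1cc(C(F)(F)F)cc(C(F)(F)F)c1)C1NCCc2ccccc21`: > 10000 nM, a limit of the assay
- compound 2 `COc1ccccc1NC(=O)C1NCCc2ccccc21`: > 10000 nM, a limit of the assay
- compound 3 `COc1ccccc1NC(=O)C1c2ccccc2CCN1C(=O)c1ccc(Cl)cc1`: 1590 nM

For the measured compounds named here, the one measured step is (4-chlorophenyl)carbonyl in place of hydrogen on an amine nitrogen in a ring, which gave an at least 6.2-fold lower number from compound 2 to compound 3 (0.79 log units; beyond the scatter). The difference between the core of compound 1 and the core of compound 2 is not broken down here; both free amines sit at the limit of > 10000 nM in this assay, at which 2 of the 3 values shown sit.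

Compound 4 `O=C(Nc1cc(C(F)(F)F)cc(C(F)(F)F)c1)C1c2ccccc2CCN1C(=O)c1ccc(Cl)cc1` is not yet measured. It stands to compound 1 as compound 3 stands to compound 2: (4-chlorophenyl)carbonyl in place of hydrogen on an amine nitrogen in a ring, the same change at the same place. For compound 1 only a limit is known, so the step can only be read against that limit, with one measured precedent behind it. From compound 1 to compound 4 a step of about an at least 4.0-fold lower number from compound 1 to compound 4 (0.60 log units; beyond the scatter) is expected in this assay, resting on an at least 6.2-fold lower number from compound 2 to compound 3 (0.79 log units; beyond the scatter). For compound 4 the estimated value in this assay is 2500 nM, between 800 nM and 8000 nM.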

Compound 4, concentration for 50% growth inhibition: 2830 nM
Compound 4: the middle estimate sits 1.1-fold (0.05 log units) below what was measured, within the range that was stated.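

In this assay, (4-chlorophenyl)carbonyl on the amine nitrogen in the ring again lowers the number on a second core, giving an at least 3.5-fold lower number from compound 1 to compound 4 (0.54 log units; beyond the scatter). The direction therefore holds on both cores shown, and neither goes against it, but the comparison of the two steps stops short of a size: the same change on two cores in this assay, an at least 6.2-fold lower number (0.79 log units; beyond the scatter) from compound 2 to compound 3 and an at least 3.5-fold lower number (0.54 log units; beyond the scatter) from compound 1 to compound 4; the limit leaves it open whether they differ. From the compounds shown here alone, each step starts from a limit rather than a number, so the full size of the change on either core stays unknown, and two cores do not establish that it carries to others: the limit of > 10000 nM in this assay, at which 2 of the 4 values shown sit.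

Going by these compounds, it remains open which part of the (4-chlorophenyl)carbonyl group goes with the lower number, and whether a plain benzoyl, an acetyl or a benzyl group on the same nitrogen would do the same. On these data alone, it is also open whether the change would carry over to a core whose anilide ring bears a nitrile or a carboxylic acid.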